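A few compounds are considered here, and "the series" means these few. Any claim that something is new, unique, unknown or untested is made for them only; others in the source may bear on it.

Values in a functional assay on QG-56 cells (Homo sapiens) for cytotoxicity, read by MTT assay, with a stated time of 48 h (on this read-out higher numbers stand for weaker inhibition and lower numbers for stronger inhibition), for the series so far:
- compound 1 `COc1cc(/C=C/C(=O)C2=C(/C=C/c3ccc(O)c(OC)c3)NC(=O)NC2c2ccccc2)ccc1O` gives 50000 nM
- compound 2 `COc1cc(/C=C/C(=O)C2=C(/C=C/c3ccc(O)c(OC)c3)NC(=O)NC2c2ccc(C)cc2)ccc1O` gives 100000 nM

Compound 2 at 100000 nM lies within the scatter of compound 1 and the two cannot be ordered on these numbers. The unmeasured compound 3 (`COc1cc(/C=C/C(=O)C2=C(/C=C/c3ccc(O)c(OC)c3)NC(=O)NC2c2ccccc2O)ccc1O`) carries 2-hydroxyphenyl in place of 4-methylphenyl on a saturated ring carbon. Among the compounds with values here, only one measured step bears on this change, and only loosely. That step (a 2.0-fold higher number from compound 1 to compound 2 (0.30 log units; within the scatter)) is methyl in place of hydrogen on an aromatic carbon and stays within the scatter. Within the data shown here, no measured compound carries the 2-hydroxyphenyl group, so the data set no direction for the change. In this assay no step beyond the scatter is therefore expected. The expected step (a 1.7-fold lower number from compound 2 to compound 3 (0.22 log units; within the scatter)) is an estimate that stays small and close to the spread of the two measured values. For compound 3 the estimate is 60000 nM with 20000 nM to 150000 nM as the expected range.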

Compound 3, half-maximal inhibitory concentration: 100000 nM
For compound 3 the middle estimate is 1.7-fold (0.22 log units) below the measured one, within the range that was stated.
By their numbers in this assay, from the lowest: compounds 1, 2 and 3 (each within the scatter of the next).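

In this assay, the change from 4-methylphenyl to 2-hydroxyphenyl on the saturated ring carbon gives no change at the digits printed from compound 2 to compound 3 (within the scatter) and so adds a hydrogen-bond donor and a hydrogen-bond acceptor at this site without a step that can be read as a change. Hydroxy in place of hydrogen on the aromatic carbon gives a 2.0-fold higher number from compound 1 to compound 3 (0.30 log units; within the scatter) and thus, like the methyl step, does not separate the substituted compound from the unsubstituted one, so compounds 1, 2 and 3 remain unordered across the three aryl groups at this position. Nothing available on these compounds accounts for this result.

The comparison of compound 2 with compound 3 changes both the group and its place on the aryl ring, so the contribution of each stays unresolved. Going by these compounds, it also remains open whether any group at this position, such as a dimethylamino or a carboxylic acid group on the aryl ring, would give a step beyond the scatter in this assay at all.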